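Working notes: hepatocyte clearance across the amine variants

The source may report more compounds than this note shows. Statements on the series, on what has been measured and on what is new or still open speak of the compounds shown alone.

Measured so far in an ADME assay on cells (Hepatocyte, Homo sapiens) for pharmacokinetics, read by LC-MS, with a stated time of 90 min, tested at 1 uM; on this read-out lower numbers stand for slow clearance and higher numbers for fast clearance:
compound 1, `C[C@@H](Nc1c(NCCCCCC(=O)NO)c(=O)c1=O)c1ccccc1`, gives < 5 uL/min, which is a limit of the assay.
compound 2, `CC(C)(Nc1c(NCCCCCC(=O)NO)c(=O)c1=O)c1ccccc1`, gives < 5 uL/min, again a limit of the assay.
compound 3, `Cc1cccc([C@@H](C)Nc2c(NCCCCCC(=O)NO)c(=O)c2=O)c1`, gives < 5 uL/min, also a limit of the assay.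

Compound 1 therefore stands only at a limit in this assay, and the two other values shown are limits as well, so no ordering among the three can be read. Among the compounds with values here, the one single-point step, a step that the two limits leave unreadable from compound 1 to compound 3, cannot be sized for the same reason. What the set does show is the limit of < 5 uL/min in this assay, at which 3 of the 3 values shown sit.

Compound 4 is `Cc1ccccc1Nc1c(NCCCCCC(=O)NO)c(=O)c1=O`. It differs from compound 1 by 2-methylphenyl in place of 1-phenylethyl on a nitrogen on an aromatic ring. Within the data shown here, no measured step bears directly on exchanging the group on that nitrogen for an aromatic ring bearing a methyl; the only neighbouring evidence is that every variant so far, including the methyl-bearing compound 3, sits at the limit, which is what the limit of < 5 uL/min in this assay, at which 3 of the 3 values shown sit, records.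

On that basis compound 4 is expected to read close to the same limit in this assay, with the step that the limit leaves unreadable from compound 1 to compound 4 expected to stay within the scatter. The estimate for compound 4 is 4 uL/min, in the range 2 uL/min to 12 uL/min.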

Compound 4, intrinsic clearance in a liver preparation (reported as CLH), per the amount of preparation that the assay uses: < 5 uL/min
Compound 4: a limit, no number; the forecaster's own chance of this, stated with the estimate: 65%; the middle value lies beyond the limit too.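

Compound 1 and compound 4 both sit at a limit, so no new step between them can be read in this assay: the limit of < 5 uL/min in this assay, at which 4 of the 4 values shown sit.

The compounds shown leave open how far any of them lies beyond that limit, and whether any change on the nitrogen would give a readable number in this assay.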